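The source may hold more compounds than are shown below. What is called first, only, known or untested is meant among the compounds shown, and "the series" means these compounds.

Measured compounds:
- compound 1, `Cn1cc([N+](=O)[O-])cc1C(=O)NNC(=O)NCc1ccco1`: in an ADME assay on Vero cells (Chlorocebus sabaeus) for cytotoxicity, read by MTT assay, with a stated time of 72 h (a lower number here means a stronger inhibitor, a higher number a weaker inhibitor), compound 1 gives 482000 nM
- compound 2, `O=C(NCc1ccco1)NNC(=O)c1cc([N+](=O)[O-])c[nH]1`: compound 2 gives 443000 nM
- compound 3, `COc1ccc(NC(=O)NNC(=O)c2cc([N+](=O)[O-])cn2C)cc1`: compound 3 gives 328000 nM

All three numbers lie within the scatter of one another; no order among them is claimed. The step of a 1.1-fold lower number from compound 1 to compound 2 (0.04 log units; within the scatter) is the change (hydrogen in place of methyl on an aromatic nitrogen). The step of a 1.5-fold lower number from compound 1 to compound 3 (0.17 log units; within the scatter) belongs to the difference between the two cores, (4-methoxyphenyl in place of (furan-2-yl)methyl on an amide-type nitrogen).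

Compound 4, `COc1ccc(NC(=O)NNC(=O)c2cc([N+](=O)[O-])c[nH]2)cc1`, is not yet measured. It differs from compound 3 by hydrogen in place of methyl on an aromatic nitrogen. The place is the same word for word as for the change from compound 1 to compound 2, so this is the same change, now made on the core of compound 3 rather than the core of compound 1. That earlier step stayed within the scatter, and the two cores themselves differ by a step that also stays within the scatter, so the step expected here, a 1.1-fold lower number from compound 3 to compound 4 (0.04 log units; within the scatter), is likewise expected to stay within the scatter, because a 1.1-fold lower number from compound 1 to compound 2 (0.04 log units; within the scatter) gave no real movement. The estimate for compound 4 is therefore 300000 nM, with a range expected from 150000 nM to 600000 nM.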

Compound 4, half-maximal inhibitory concentration: 401000 nM
Compound 4: middle estimate off by 1.3-fold (0.13 log units), on the low side; measured number inside the range.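

In this assay, hydrogen in place of methyl on an aromatic nitrogen gives a 1.2-fold higher number from compound 3 to compound 4 (0.09 log units; within the scatter), so on this core as well the change brings no real movement. Set beside the earlier step, the change behaves alike on both cores, with no difference between them beyond the scatter: the same change on two cores in this assay, a 1.1-fold lower number (0.04 log units; within the scatter) from compound 1 to compound 2 and a 1.2-fold higher number (0.09 log units; within the scatter) from compound 3 to compound 4, 1.3-fold (0.12 log units) apart, within the scatter of two such steps

For the compounds shown here, this shows only that the change stays silent on two cores in this assay; with no step beyond the scatter, it does not show that any real effect carries from one core to another, and it says nothing about other cores or other read-outs.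

The compounds shown carry only hydrogen or methyl on the aromatic nitrogen, and only (furan-2-yl)methyl or 4-methoxyphenyl on the amide-type nitrogen. As far as these compounds go, it remains open whether a longer chain on the aromatic nitrogen, or an amine or a carboxylic acid in place of the nitro group, would move the number beyond the scatter.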